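A few compounds are considered here, and "the series" means these few. Any claim that something is new, unique, unknown or untested is made for them only; others in the source may bear on it.

Series notes. Compound 1 `CC1CCCc2ncc(C(=O)O)c(=O)n21` carries the shared core; in a functional assay on the whole organism for inhibition, with Rattus norvegicus as the target (on this read-out lower numbers stand for an effect already at smaller amounts and higher numbers for an effect only at larger amounts of compound), compound 1 gives 240 umol/kg. Compound 2 `CCOC(=O)c1cnc2n(c1=O)C(C)CC/C2=N\Nc1ccccc1C(=O)O` adds the aryl hydrazone bearing 2-carboxyphenyl, and in this assay compound 2 gives 10 umol/kg, the lower of the two numbers recorded, with the gap to compound 1 beyond the usual scatter. Compound 3 `CCOC(=O)c1cnc2n(c1=O)C(C)CC/C2=N\Nc1ccc(C(=O)O)cc1` differs from compound 2 only in the change (4-carboxyphenyl in place of 2-carboxyphenyl on an amine nitrogen). Among the compounds with values here, no comparable step is available, so the step from compound 2 to compound 3 is expected to be modest and, if anything, toward a higher number, a 2.0-fold higher number from compound 2 to compound 3 (0.30 log units; within the scatter). Compound 3 is therefore estimated at 20 umol/kg, with a range of 5 umol/kg to 80 umol/kg.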

Compound 3, dose for 50% inhibition: 100 umol/kg
Compound 3: the middle estimate sits 5.0-fold (0.70 log units) below what was measured, outside the stated range (above it).
By their numbers in this assay, from the lowest: compound 2; then compound 3; then compound 1.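

In this assay the step is a 10-fold higher number from compound 2 to compound 3 (1.00 log units; beyond the scatter), for 4-carboxyphenyl in place of 2-carboxyphenyl on an amine nitrogen. The two groups have the same atoms and the same counts, so at this position the placement of the carboxyl group on the phenyl ring alone changes the read-out beyond the scatter. Nothing available bears on what lies behind this gap. Open, from the compounds shown here alone, is where 3-carboxyphenyl or unsubstituted phenyl would fall relative to compound 2 and compound 3, and whether a methyl ester in place of the carboxylic acid would keep the same order.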